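A few compounds are considered here, and "the series" means these few. Any claim that something is new, unique, unknown or untested is made for them only; others in the source may bear on it.

Compound 3 `CC(C)c1cccc(C(C)C)c1NC(=O)NCC1(c2cccc([N+](=O)[O-])c2)CCCC1` gives 51 nM in an assay on microsomes for inhibition of acyl-CoA:cholesterol acyltransferase (Oryctolagus cuniculus) (a higher number here means a weaker inhibitor, a lower number a stronger inhibitor), the largest of the three numbers, though within the scatter of both companions. Compound 1 `CC(C)c1ccc(C2(CNC(=O)Nc3c(C(C)C)cccc3C(C)C)CCCC2)cc1` gives 48 nM in this assay, and compound 2 `CC(C)c1cccc(C(C)C)c1NC(=O)NCC1(c2cccc(OCc3ccccc3)c2)CCCC1` gives 30 nM. The steps of a 1.1-fold higher number from compound 1 to compound 3 (0.03 log units; within the scatter) and a 1.7-fold higher number from compound 2 to compound 3 (0.23 log units; within the scatter) both stay within the scatter. Compound 4 `CC(C)c1cccc(C(C)C)c1NC(=O)NCC1(c2cccc(C(=O)O)c2)CCCC1` differs from compound 3 by carboxy in place of nitro on an aromatic carbon. Within the data shown here, the step from compound 2 to compound 3 is the nearest precedent, a change of substituent on the same aromatic carbon, and it was small; the swap of the whole aryl group from compound 1 to compound 3 was likewise small. Compound 4 is therefore expected to show no step beyond the scatter in this assay, a 1.6-fold higher number from compound 3 to compound 4 (0.20 log units; within the scatter), with a wide range for caution. Compound 4 is estimated at 80 nM, between 25 nM and 300 nM.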

Compound 4, half-maximal inhibitory concentration: 620 nM
Beside the measured number, compound 4's estimate is 7.8-fold (0.89 log units) below it; the whole stated range lies below it.
By their numbers in this assay, from the lowest: compounds 2, 1 and 3 (each within the scatter of the next); then compound 4.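

Nitro and benzyloxy on this aromatic carbon stayed within the scatter of each other, so the earlier compounds showed no sensitivity here, but carboxy brings a 12-fold higher number from compound 3 to compound 4 (1.08 log units; beyond the scatter) in this assay and a 21-fold higher number from compound 2 to compound 4 (1.32 log units; beyond the scatter). The comparison with the 4-isopropylphenyl of compound 1 is also large, at a 13-fold higher number from compound 1 to compound 4 (1.11 log units; beyond the scatter). Nitro and carboxy have the same heavy-atom count, so that count alone does not follow the number here. Nothing given accounts for these steps. Going by these compounds, whether a methyl ester or a primary amide on this carbon would behave like carboxy or like nitro stays open.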